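A Bromine Added to the Phenyl Ring of Compound 3

This account rests on a few compounds, and the source may have more. Where it says the series, first, only, none or still open, it means among the compounds named here.

The measured compounds and their values:
- Compound 1 `CN1CCC(n2cc(S(=O)(=O)c3ccccc3)c3cccnc32)C1`: in an assay on HeLa cells for displacement of a labelled ligand from 5-hydroxytryptamine receptor 6 (Homo sapiens) (a higher number here means a weaker inhibitor, a lower number a stronger inhibitor), compound 1 gives 2.5 nM.
- Compound 2 `CCN1CCC(n2cc(S(=O)(=O)C3=C(Cl)NC4SC=CN34)c3cccnc32)C1`: in this assay compound 2 gives 1.4 nM.
- Compound 3 `O=S(=O)(c1ccccc1)c1cn(C2CCCNC2)c2ncccc12`: in this assay compound 3 gives 4.9 nM.

Compound 3 holds the highest of the three numbers. Among the measured compounds shown here, its nearest neighbour is compound 1, and the one measured step, a 2.0-fold higher number from compound 1 to compound 3 (0.29 log units; within the scatter), lies within the scatter, so the two cannot be told apart. Compound 2 is the furthest from compound 3, with a gap beyond the scatter.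

Compound 4 `O=S(=O)(c1cccc(Br)c1)c1cn(C2CCCNC2)c2ncccc12` differs from compound 3 in one place: bromo in place of hydrogen on an aromatic carbon. For the measured compounds named here, the only measured step concerns the group on the aromatic nitrogen, not the phenyl ring, so no measured step bears on this change; the data give no guide to a substituent on that ring. With nothing to point one way or the other, the expectation is a step of no size beyond the scatter, no change at the digits printed from compound 3 to compound 4 (within the scatter). Compound 4 is therefore expected to give about 4.9 nM in this assay, with a range from 1.5 nM to 16 nM.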

Compound 4, inhibition constant: 3.8 nM
For compound 4 the middle estimate is 1.3-fold (0.11 log units) above the measured one; low and high end bracket the measured number.
By their numbers in this assay, from the lowest: compounds 2, 1, 4 and 3 (each within the scatter of the next, the first and the last beyond it).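

Among the compounds shown here, until now the phenyl ring had carried no substituent in any compound that allowed a comparison, so this is the first reading on it: in this assay the step is a 1.3-fold lower number from compound 3 to compound 4 (0.11 log units; within the scatter). Compound 3 and compound 4 therefore cannot be told apart, which shows that bromo, a single heavy atom on an aromatic carbon meta to a large group, can enter this ring with no measurable consequence for the number, and compound 4 stays at 3.8 nM. Nothing in the data shown speaks to the reason for this result.

On these data alone, it remains open whether a group other than bromo at this place, such as an amine, a carboxylic acid or a longer alkyl chain, would also leave the number within the scatter, and whether bromo on another carbon of the phenyl ring would read the same. Also open, as far as these compounds go, is whether bromo would give the same step with the 1-methylpyrrolidin-3-yl group of compound 1 on the aromatic nitrogen in place of piperidin-3-yl.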